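Pyridinyl for fluorophenyl on the piperazine of a caffeic amide

The compounds below may be only part of what the source reports. "The series", "measured", "known", "first", "only" and "open" are said of these compounds alone.

Measured compounds:
compound 1 `O=C(/C=C/c1ccc(O)c(O)c1)N1CCN(c2ccccc2F)CC1`, 2.43 ug/mL
compound 2 `O=C(/C=C/c1ccc(O)c(O)c1)N1CCN(c2cccc(Cl)c2)CC1`, 1.71 ug/mL
compound 3 `Cc1ccc(N2CCN(C(=O)/C=C/c3ccc(O)c(O)c3)CC2)c(C)c1`, 1.43 ug/mL

In a functional assay on B16-F10 cells (Mus musculus) for antiproliferative activity, read by MTT assay, with a stated time of 48 h (a lower number here means a stronger inhibitor, a higher number a weaker inhibitor), compound 1 gives the highest of the three numbers, yet a 1.4-fold lower number from compound 1 to compound 2 (0.15 log units; within the scatter) and a 1.7-fold lower number from compound 1 to compound 3 (0.23 log units; within the scatter) both sit within the scatter, as does a 1.2-fold lower number from compound 2 to compound 3 (0.08 log units; within the scatter). Compound 4 `O=C(/C=C/c1ccc(O)c(O)c1)N1CCN(c2ccccn2)CC1` is not yet measured. It differs from compound 1 by pyridin-2-yl in place of 2-fluorophenyl on an amine nitrogen in a ring. Going by the values given here, the steps that bear on it are those in which the aryl group on the amine nitrogen in the ring was exchanged, and all of them were within the scatter. Compound 4 is therefore expected to give 2.2 ug/mL in this assay, within 1 ug/mL to 5 ug/mL. This estimate means a step of a 1.1-fold lower number from compound 1 to compound 4 (0.04 log units; within the scatter), expected to stay within the scatter.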

Compound 4, half-maximal inhibitory concentration: 3.01 ug/mL
Beside the measured number, compound 4's estimate is 1.4-fold (0.14 log units) below it; the range from low to high includes it.
By their numbers in this assay, from the lowest: compounds 3, 2, 1 and 4 (each within the scatter of the next, the first and the last beyond it).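

In this assay, going by these compounds alone, pyridin-2-yl, the first group here to bring a ring nitrogen and a hydrogen-bond acceptor to this place, leaves the number level with 2-fluorophenyl (a 1.2-fold higher number from compound 1 to compound 4 (0.09 log units; within the scatter)) and with 3-chlorophenyl (a 1.8-fold higher number from compound 2 to compound 4 (0.25 log units; within the scatter)). Within the data shown here, only against 2,4-dimethylphenyl does the exchange pass beyond the scatter (a 2.1-fold higher number from compound 3 to compound 4 (0.32 log units; beyond the scatter)), the first step at this place to do so, and a modest one. Nothing measured here accounts for that step. Open, going by these compounds, is whether an aryl group carrying an amine or a carboxylic acid, or a plain alkyl chain in place of the aryl group, would move the number further.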